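The source may hold more compounds than are shown below. What is called first, only, known or untested is meant among the compounds shown, and "the series" means these compounds.

Compound 1 `CCCS(=O)(=O)Nc1ccc(F)c(C(=O)c2n[nH]c3ncc(-c4cccc(N)c4)cc23)c1F`: 1.6%
Compound 2 `CCCS(=O)(=O)Nc1ccc(F)c(C(=O)c2n[nH]c3ncc(-c4ccc(Cl)c(C(F)(F)F)c4)cc23)c1F`: 15%

Of the compounds shown here, two built on one shared core have been measured in an assay for binding affinity to dual specificity mitogen-activated protein kinase kinase 4 (Homo sapiens), read by KINOMEscan, tested at 100 nM; a lower number here means a stronger effect, a higher number a weaker effect of the compound at the concentration tested. Compound 1 `CCCS(=O)(=O)Nc1ccc(F)c(C(=O)c2n[nH]c3ncc(-c4cccc(N)c4)cc23)c1F` gives 1.6%, and compound 2 `CCCS(=O)(=O)Nc1ccc(F)c(C(=O)c2n[nH]c3ncc(-c4ccc(Cl)c(C(F)(F)F)c4)cc23)c1F` gives 15%. Compound 2 stands highest of the two numbers; its nearest neighbour is compound 1, from which it is separated by the step of a number 13.4 percentage points higher from compound 1 to compound 2 (beyond the scatter), a modest step beyond the scatter.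

Compound 3 `CCCS(=O)(=O)Nc1ccc(F)c(C(=O)c2n[nH]c3ncc(-c4ccc(C(F)(F)F)cc4)cc23)c1F` has not yet been measured in this assay. It differs from compound 2 by 4-(trifluoromethyl)phenyl in place of 4-chloro-3-(trifluoromethyl)phenyl on an aromatic carbon. The change sits on an aromatic carbon of the six-membered ring with one nitrogen in the fused two-ring system, two atoms from the ring nitrogen. Going by the values given here, only one measured step touches this position, a number 13.4 percentage points higher from compound 1 to compound 2 (beyond the scatter), and it was modest. Among the compounds with values here, no measured pair shows this particular exchange, so the expectation rests on that single step alone. The step of a number 3 percentage points lower from compound 2 to compound 3 (within the scatter) is therefore expected to be small, and probably within the scatter, with a slight lean toward a lower number. Compound 3 is estimated at 12%, with a range from 3% to 35%.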

Compound 3, a percentage reported as activity, at one concentration (the size of the read-out at that concentration, not a potency): 29%
Compound 3: the middle estimate sits 17 percentage points below what was measured; low and high end bracket the measured number.
By their numbers in this assay, from the lowest: compound 1; then compound 2; then compound 3.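

In this assay the step of a number 14 percentage points higher from compound 2 to compound 3 (beyond the scatter) shows that this position responds not only to replacing 3-aminophenyl with a different aryl group but also to a smaller edit within such a group, since 4-(trifluoromethyl)phenyl differs from 4-chloro-3-(trifluoromethyl)phenyl by lacking the chlorine. The step of a number 27.4 percentage points higher from compound 1 to compound 3 (beyond the scatter) widens the span seen at this position, and among these three groups the order by number runs from 3-aminophenyl through 4-chloro-3-(trifluoromethyl)phenyl to 4-(trifluoromethyl)phenyl, so the two groups bearing trifluoromethyl do not read alike here. No supporting evidence is available to explain why these numbers differ.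

From the compounds shown here alone, what remains open is how far the lowest number belongs to the amine itself and how far to its place on the phenyl ring, a question that a 4-aminophenyl or 3-hydroxyphenyl group would address. Going by these compounds, it is equally open whether chlorine alone would carry the effect seen here, as a 4-chlorophenyl group would test, and whether a carboxylic acid on the phenyl ring would fit the same order.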